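One Aryl Change in a Shared Core, Awaiting Measurement

This account rests on a few compounds, and the source may have more. Where it says the series, first, only, none or still open, it means among the compounds named here.

Measured so far:
compound 1 `CCOC(=O)c1c(N)sc(/N=C/c2ccc([N+](=O)[O-])o2)c1C(=O)OCC` — 2400 nM
compound 2 `CCOC(=O)c1c(N)sc(/N=C/c2ccncc2)c1C(=O)OCC` — 92200 nM

Of the compounds shown here, two have been measured in a functional assay on MCF7 cells (Homo sapiens) for inhibition, read by MTT assay, with a stated time of 48 h; a lower number here means a stronger inhibitor, a higher number a weaker inhibitor. Compound 1 gives the lowest of the two numbers, 2400 nM, and its nearest neighbour is compound 2, with 92200 nM. Among the compounds with values here, the single measured step, a 38-fold higher number from compound 1 to compound 2 (1.58 log units; beyond the scatter), is large and beyond the scatter; it is also the only step that bears on the new compound, since in both cases the 5-nitrofuran-2-yl group on the carbon with a double bond to nitrogen gives way to a six-membered aromatic ring.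

Compound 3 `CCOC(=O)c1c(N)sc(/N=C/c2ccc(C)cc2)c1C(=O)OCC` differs from compound 1 in one place: 4-methylphenyl in place of 5-nitrofuran-2-yl on a carbon with a double bond to nitrogen. Within the data shown here, with compound 2 as the only guide, compound 3 is expected to land at a higher number than compound 1 in this assay, a step of about a 17-fold higher number from compound 1 to compound 3 (1.22 log units; beyond the scatter), though the size is uncertain, as 4-methylphenyl and pyridin-4-yl are not the same group. The estimate for compound 3 is therefore 40000 nM, within a range from 8000 nM to 200000 nM.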

Compound 3, half-maximal inhibitory concentration: 8900 nM
Estimate against measurement, compound 3: 4.5-fold (0.65 log units) above; measured number inside the range.
By their numbers in this assay, from the lowest: compound 1; then compound 3; then compound 2.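

In this assay the position on the carbon with a double bond to nitrogen does not depend on the 5-nitrofuran-2-yl group alone: exchanging it for 4-methylphenyl gives a 3.7-fold higher number from compound 1 to compound 3 (0.57 log units; beyond the scatter) and so costs far less than the exchange for pyridin-4-yl did. The two six-membered aromatic rings also part widely, with a 10-fold lower number from compound 2 to compound 3 (1.02 log units; beyond the scatter) for the exchange of pyridin-4-yl for 4-methylphenyl, which shows that the large earlier step cannot be read as the loss of 5-nitrofuran-2-yl alone and that what enters here counts as well as what leaves. Nothing measured here accounts for either step.

The compounds shown leave the nitro group and the furan ring unseparated, as 5-nitrofuran-2-yl leaves as a whole, so a plain furan-2-yl or a phenyl ring carrying a nitro group would be needed to tell their shares apart. Also open is what the methyl group of 4-methylphenyl contributes, which a plain phenyl ring could show, and how a phenyl ring carrying an amine or a carboxylic acid would fall among these three compounds.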